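A Methyl Added to Compound 2

A few compounds are considered here, and "the series" means these few. Any claim that something is new, unique, unknown or untested is made for them only; others in the source may bear on it.

Two compounds frame this step. Going by the values given here, in a functional assay on the whole organism for agonist activity, with Mus musculus as the target (a lower number here means that less compound is needed, a higher number that more compound is needed for the effect), compound 1 `COC(=O)N(C)C(C)C#CCN1CCCC1` gives 20.9 mg/kg, the only true number so far. As far as these compounds go, compound 2 `CCOC(=O)N(C)CC#CCN1CCCC1` is recorded as > 100 mg/kg, which is a limit of the assay and not a number, so its actual position remains unknown.

Compound 3 `CCOC(=O)N(C)C(C)C#CCN1CCCC1` is derived from compound 2 by one change: methyl in place of hydrogen on a saturated chain carbon bound to an amide-type nitrogen and a triple-bonded carbon. Among the compounds with values here, no measured pair isolates this change, so its effect has not been observed directly. The expectation rests on little more than the presence of compound 1 with 20.9 mg/kg, which shows that a measurable dose can be reached within this small set.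

In this assay, a move towards a lower dose, beyond the usual scatter, is expected, though a result that is again only a limit remains quite possible. The expected step is an at least 2.5-fold lower number from compound 2 to compound 3 (0.39 log units; beyond the scatter). For compound 3 the estimate is 40 mg/kg, with an expected range from 12 mg/kg to 100 mg/kg.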

Compound 3, dose for half-maximal effect: > 100 mg/kg
Compound 3: no number, only a limit; the forecaster's own chance of this, stated with the estimate: 35%; at least 2.5-fold (0.39 log units) between middle value and limit.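

The added methyl, on a saturated chain carbon bound to an amide-type nitrogen and a triple-bonded carbon, does not bring compound 3 to a measurable dose in this assay: compound 3 gives > 100 mg/kg, which is a limit of the assay and not a number. The new information comes from another place, where methyl in place of hydrogen on a saturated chain carbon bound to an oxygen next to a carbonyl group gives an at least 4.7-fold higher number from compound 1 to compound 3 (0.67 log units; beyond the scatter), so that with the chain methyl present, this one change separates a measured dose from a limit. The step for the chain methyl itself cannot be read, because both of its compounds stand at a limit: the limit of > 100 mg/kg in this assay, at which 2 of the 3 values shown sit.

As far as these compounds go, how far the true doses of compound 2 and compound 3 lie past that limit remains open, and so does whether the chain methyl changes the dose at all. Also open, from the compounds shown here alone, is what an ethyl group on that same chain carbon, or a propyl chain on the oxygen, would give in this assay.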